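The source may report more compounds than this note shows. Statements on the series, on what has been measured and on what is new or still open speak of the compounds shown alone.

Measured compounds:
compound 1 `COc1ccc(N(CC(=O)NCCC[Te]c2ccccc2)C(=O)CNC(=O)OC(C)(C)C)cc1` — in a functional assay on HT-29 cells (Homo sapiens) for inhibition, with a stated time of 48 h (a lower number here means that less compound is tolerated, a higher number that more compound is tolerated), compound 1 gives < 100000 nM, which is a limit of the assay rather than a number.
compound 2 `COc1ccc(N(CC(=O)NCCC[Te]c2ccccc2)C(=O)CCSC2=C(C)C(=O)c3ccccc3C2=O)cc1` — in this assay compound 2 gives 50100 nM.

Compound 1 therefore stands at the limit of < 100000 nM in this assay, at which 1 of the 2 values shown sits, so only a bound is known for it, not a value. Within the data shown here, compound 2 has a full number, but with no step between the two in the same place of the structure, all that can be said is what each value shows on its own: both are weak.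

The unmeasured compound 3 `COc1ccc(N(CC(=O)NCCC[Te]c2ccccc2)C(=O)c2ccccc2)cc1` differs from compound 1 by phenyl in place of ((tert-butoxycarbonyl)amino)methyl on a carbonyl carbon. Among the measured compounds shown here, since no measured pair covers this change, the expectation for the step from compound 1 to compound 3 rests on the two weak values alone, and the estimated step that the limit leaves unreadable from compound 1 to compound 3 is taken as none beyond the scatter, with no clear direction. Compound 3 is expected to give about 40000 nM, with a range from 10000 nM to 100000 nM.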

Compound 3, concentration lethal to 50% of the cells: < 100000 nM
Compound 3 was reported as a limit (the forecaster's own chance of this, stated with the estimate: 30%); the middle value is on the limit's open side.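

Compound 1 and compound 3 are both reported in this assay only as limits rather than numbers, so no step between them can be read: the limit of < 100000 nM in this assay, at which 2 of the 3 values shown sit.

The compounds shown leave open whether phenyl in place of ((tert-butoxycarbonyl)amino)methyl on a carbonyl carbon changes the lethal concentration at all, and if so, in which direction and by how much.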